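Solubility notes: amino for hydroxy on the side chain

The compounds below may be only part of what the source reports. "The series", "measured", "known", "first", "only" and "open" are said of these compounds alone.

Compound 1 `COCCCNc1nnc(-c2ccc(F)c(F)c2Nc2ccc(I)cc2F)o1` and compound 2 `OCCNc1nnc(-c2ccc(F)c(F)c2Nc2ccc(I)cc2F)o1` share one core and differ only on the side chain. In a physicochemical assay for solubility, read by HPLC, in phosphate buffer, at pH 6.5 (a lower number here means a less soluble compound, a higher number a more soluble compound), compound 1 gives a limit, < 3 ug/mL. In this assay compound 2 also gives a limit, < 3 ug/mL. The step that the two limits leave unreadable from compound 1 to compound 2 therefore cannot be sized, and the limit of < 3 ug/mL in this assay, at which 2 of the 2 values shown sit, is all the series shows so far. Compound 3 `NCCNc1nnc(-c2ccc(F)c(F)c2Nc2ccc(I)cc2F)o1` carries the change (amino in place of hydroxy on a saturated chain carbon, two bonds along the chain from a nitrogen on an aromatic ring). Among the measured compounds shown here, no measured step bears on this change; both values are limits, so the size of the step from hydroxy to amino at this place is not set by anything measured here. The expected step is an at least 4.0-fold higher number from compound 2 to compound 3 (0.60 log units; beyond the scatter), upward, but with wide uncertainty and a real chance that the assay again returns only a limit. Compound 3 is estimated at 12 ug/mL, with a range from 2 ug/mL to 70 ug/mL.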

Compound 3, solubility: < 3 ug/mL
Compound 3: no number, only a limit; the forecaster's own chance of this, stated with the estimate: 35%; middle value at least 4.0-fold (0.60 log units) from the limit.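

In this assay compound 3 returns only a limit, as do compound 1 and compound 2, so no step among these three compounds can be read: the limit of < 3 ug/mL in this assay, at which 3 of the 3 values shown sit. Going by these compounds, the actual solubility of each compound, and whether the side-chain changes alter it at all, remain open.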